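The source may report more compounds than this note shows. Statements on the series, on what has been measured and on what is new or still open speak of the compounds shown alone.

- Compound 1 `CC(C)COC(=O)N1CCCc2cc(S(=O)(=O)N3CC(c4ccccc4)NC3=O)ccc21` gives 5650 nM
- Compound 2 `O=C(c1ccccc1)N1CCCc2cc(S(=O)(=O)N3CC(c4ccccc4)NC3=O)ccc21` gives 8560 nM
- Compound 3 `O=C1NC(c2ccccc2)CN1S(=O)(=O)c1ccc2c(c1)CCCN2C(=O)C(F)(F)F` gives 19600 nM

In a functional assay on SK-OV-3 cells (Homo sapiens) for antiproliferative activity, read by MTT assay (a higher number here means a weaker inhibitor, a lower number a stronger inhibitor), compound 1 gives 5650 nM and sits level with compound 2 within the scatter, while compound 3 lies higher. Compound 4 `O=C(CCl)NC(=O)N1CCCc2cc(S(=O)(=O)N3CC(c4ccccc4)NC3=O)ccc21` is still unmeasured and puts ((chloromethyl)carbonyl)amino in place of isobutoxy on a carbonyl carbon. Going by the values given here, two measured steps replace the same isobutoxy, and neither is large: a 1.5-fold higher number from compound 1 to compound 2 (0.18 log units; within the scatter) and a 3.5-fold higher number from compound 1 to compound 3 (0.54 log units; beyond the scatter) are the only guides. Going by these compounds, neither of those entering groups contains chlorine, so the direction stays open, and no clear change is expected (a 1.3-fold lower number from compound 1 to compound 4 (0.10 log units; within the scatter)). The expected value for compound 4 is 4500 nM with a range from 800 nM to 14000 nM as a deliberately wide estimate.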

Compound 4, half-maximal inhibitory concentration: 6140 nM
For compound 4 the middle estimate is 1.4-fold (0.13 log units) below the measured one; low and high end bracket the measured number.
By their numbers in this assay, from the lowest: compounds 1, 4 and 2 (each within the scatter of the next); then compound 3.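

In this assay, a hydrogen-bond donor and a chlorine can enter on this carbonyl carbon with no clear effect: ((chloromethyl)carbonyl)amino gives a 1.1-fold higher number from compound 1 to compound 4 (0.04 log units; within the scatter) and a 1.4-fold lower number from compound 2 to compound 4 (0.14 log units; within the scatter). Isobutoxy, phenyl and this new group therefore sit level despite their different atoms, while trifluoromethyl goes against that pattern, with a 3.2-fold lower number from compound 3 to compound 4 (0.50 log units; beyond the scatter). Nothing available here bears on the reason for this.

Going by these compounds, whether the chlorine matters stays open, as an acetylcarbamoyl group, with methyl in place of chloromethyl, would show. How an amine or a carboxylic acid would behave on this carbonyl carbon is also unknown.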